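The Same Aryl Swap Tried on a Second Core

This account rests on a few compounds, and the source may have more. Where it says the series, first, only, none or still open, it means among the compounds named here.

Compound 1 `O=C(Nc1ccc(Oc2ccnc3[nH]ccc23)c(F)c1)c1cc2cccnc2n(-c2ccc(Br)cc2F)c1=O` and compound 3 `Cn1ccc2c(Oc3ccc(NC(=O)c4cc5cccnc5n(-c5ccc(Br)cc5F)c4=O)cc3)ccnc21` differ in more than one place, and the difference between the two cores is not broken down here. In a functional assay on A549 cells (Homo sapiens) for antiproliferative activity, read by MTT assay, with a stated time of 72 h (on this read-out higher numbers stand for weaker inhibition and lower numbers for stronger inhibition), compound 1 gives 460 nM, while compound 3 gives 1630 nM. Compound 2 `O=C(Nc1ccc(Oc2ccnc3[nH]ccc23)c(F)c1)c1cc2cccnc2n(-c2ccc(C(F)(F)F)cc2Cl)c1=O` is reached from compound 1 by 2-chloro-4-(trifluoromethyl)phenyl in place of 4-bromo-2-fluorophenyl on an aromatic nitrogen, a change that gave a 2.2-fold higher number from compound 1 to compound 2 (0.35 log units; beyond the scatter), so that compound 2 gives 1020 nM. Compound 4 `Cn1ccc2c(Oc3ccc(NC(=O)c4cc5cccnc5n(-c5ccc(C(F)(F)F)cc5Cl)c4=O)cc3)ccnc21` applies the same change to compound 3, (2-chloro-4-(trifluoromethyl)phenyl in place of 4-bromo-2-fluorophenyl on an aromatic nitrogen). Compound 4 is expected to show a 2.1-fold higher number from compound 3 to compound 4 (0.33 log units; beyond the scatter) because the same change gave a 2.2-fold higher number from compound 1 to compound 2 (0.35 log units; beyond the scatter), although a single prior instance on a different core is a thin basis. Compound 4 is therefore estimated at 3500 nM in this assay, most plausibly between 1600 nM and 8000 nM.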

Compound 4, half-maximal inhibitory concentration: 8250 nM
For compound 4 the middle estimate is 2.4-fold (0.37 log units) below the measured one; measured number outside the range, above it.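

In this assay, the swap to 2-chloro-4-(trifluoromethyl)phenyl also raised the number on the second core, giving a 5.1-fold higher number from compound 3 to compound 4 (0.70 log units; beyond the scatter). The direction therefore carried over, and the sizes of the two steps cannot be told apart: the same change on two cores in this assay, a 2.2-fold higher number (0.35 log units; beyond the scatter) from compound 1 to compound 2 and a 5.1-fold higher number (0.70 log units; beyond the scatter) from compound 3 to compound 4, 2.3-fold (0.36 log units) apart, within the scatter of two such steps. This rests on just two pairs, so it shows the same direction on these two cores only and does not show how the change would behave on any other core.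

The compounds shown leave open how an aryl group carrying an amine or a carboxylic acid would fare on the aromatic nitrogen of either core. They also do not separate the chloro group from the trifluoromethyl group, as these enter together in both pairs.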